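Dropping a Hydroxy Group from a Near-Inactive Kinase Inhibitor

This account rests on a few compounds, and the source may have more. Where it says the series, first, only, none or still open, it means among the compounds named here.

Compound 1, `NC(=O)c1sc2ccccc2c1O`: > 100000 nM
Compound 2, `NC(=O)c1sc2cccnc2c1N`: 92000 nM
Compound 3, `Nc1c(C(=O)O)sc2ncccc12`: > 100000 nM

In an assay on isolated protein for inhibition of LIM domain kinase 1 (Homo sapiens), read by Kinase-Glo, with a stated time of 60 min (on this read-out higher numbers stand for weaker inhibition and lower numbers for stronger inhibition), compound 1 gives only a limit, > 100000 nM, not a number. Compound 1 thus stands at the limit of > 100000 nM in this assay, at which 2 of the 3 values shown sit. Compound 2 gives a measured value in this assay, 92000 nM. Compound 3 gives only a limit, > 100000 nM.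

Compound 4, `NC(=O)c1cc2ccccc2s1`, differs from compound 1 by hydrogen in place of hydroxy on an aromatic carbon. Going by the values given here, no step between measured compounds sizes this change, and the starting point is itself a limit, so no shift beyond the usual scatter is expected. Compound 4 is therefore expected to stay near the limit, a step that the limit leaves unreadable from compound 1 to compound 4, with an estimated 150000 nM in the range 50000 nM to 500000 nM, and this assay will most likely again return only a limit for compound 4.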

Compound 4, half-maximal inhibitory concentration: > 100000 nM
Compound 4 was reported as a limit; the forecaster's own chance of this, stated with the estimate: 80%; the middle value is on the limit's open side.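

Going by these compounds alone, compound 1 and compound 4 both come back only as limits, so no step between them can be read: the limit of > 100000 nM in this assay, at which 3 of the 4 values shown sit. On these data alone, whether hydrogen in place of hydroxy changes inhibition at all in this assay stays open.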